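Moving the Alkoxy Group on the Aniline Ring

A few compounds are considered here, and "the series" means these few. Any claim that something is new, unique, unknown or untested is made for them only; others in the source may bear on it.

Of the compounds shown here, three sharing one core have been tested in a functional assay on ECa-109 cells for inhibition, with ECa-109 cell line (Homo sapiens) as the target, read by sulforhodamine B assay; a lower number here means a stronger inhibitor, a higher number a weaker inhibitor. For the measured compounds named here, compound 1 `O=C1C(Nc2ccc(I)cc2)=CC(=O)c2c1nc1n2[C@H]2OC[C@@H](O)[C@H]2OC1` gives 2530 nM, the only true number in the set. Compound 2 `O=C1C(N2CCCCC2)=CC(=O)c2c1nc1n2[C@H]2OC[C@@H](O)[C@H]2OC1` is known only as a limit, > 8000 nM. Compound 3 `CCOc1ccc(NC2=CC(=O)c3c(nc4n3[C@H]3OC[C@@H](O)[C@H]3OC4)C2=O)cc1` is also known only as a limit, > 4000 nM. Its true position on the scale is therefore open.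

The next compound is compound 4 `COc1cccc(NC2=CC(=O)c3c(nc4n3[C@H]3OC[C@@H](O)[C@H]3OC4)C2=O)c1`, which has 3-methoxyphenyl in place of 4-ethoxyphenyl on an amine nitrogen. Going by the values given here, no measured step makes this exact change. The closer guide is the exchange of iodo for ethoxy on an aromatic carbon, an at least 1.5-fold higher number from compound 1 to compound 3 (0.19 log units; that floor lies within the scatter), whose floor lies within the scatter. The exchange of (4-iodophenyl)amino for piperidin-1-yl, an at least 3.1-fold higher number from compound 1 to compound 2 (0.49 log units; beyond the scatter), was larger, but it removes the aromatic ring, whereas compound 4 keeps one on the amine nitrogen.

The change is therefore expected to be small and to stay within the scatter, with no firm direction. The expected step is a step that the limit leaves unreadable from compound 3 to compound 4. A limit rather than a number may well be reported again. The estimated value for compound 4 is 4500 nM, with an expected range of 2000 nM to 10000 nM.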

Compound 4, half-maximal inhibitory concentration: 3340 nM
Estimate against measurement, compound 4: 1.3-fold (0.13 log units) above; low and high end bracket the measured number.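

In this assay, the 3-methoxyphenyl group on the amine nitrogen gives compound 4 a true number, whereas compound 3, with 4-ethoxyphenyl at that place, is known only as a limit: the limit of > 4000 nM in this assay, at which 1 of the 4 values shown sits.

The comparison of these two therefore gives only a floor, an at least 1.1-fold lower number from compound 3 to compound 4 (0.07 log units; that floor lies within the scatter), so its real size cannot be read, while the exchange of 4-iodophenyl for 3-methoxyphenyl on the amine nitrogen gives a 1.3-fold higher number from compound 1 to compound 4 (0.12 log units; within the scatter), which leaves those two compounds level. The step of an at least 2.3-fold lower number from compound 2 to compound 4 (0.37 log units; beyond the scatter) starts from a limit for compound 2, and it adds a second aromatic example to compound 1 in standing apart from the piperidin-1-yl compound, although compound 3 cannot yet be placed in that comparison.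

Compound 3 and compound 4 differ both in the length of the alkoxy chain and in where it sits on the ring, so the shown values cannot separate the two changes. A 4-methoxyphenyl or 3-ethoxyphenyl group would pull them apart, and a 3-aminophenyl group would test whether the ring oxygen is needed at all.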